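Adding a second chlorine to the core of compound 1

The source may report more compounds than this note shows. Statements on the series, on what has been measured and on what is new or still open speak of the compounds shown alone.

Measured compounds:
compound 1, `ClCc1ccc(Cn2cnc3c(Cl)ncnc32)cc1`: 26900 nM
compound 2, `ClCc1ccccc1Cn1cnc2c(Cl)ncnc21`: > 100000 nM
compound 3, `ClCc1ccc(Cn2cnc3nc(Cl)nc(Cl)c32)cc1`: 79400 nM

In a functional assay on NCI-H460 cells (Homo sapiens) for cytotoxicity, read by sulforhodamine B assay, with a stated time of 48 h (on this read-out lower numbers stand for higher toxicity in this test and higher numbers for lower toxicity in this test), compound 1 gives 26900 nM, the lower of the two numbers recorded. Compound 3, which bears two chlorines on its core, gives 79400 nM in this assay, a higher number that lies beyond the scatter of the test. For compound 2 this assay reports only a limit, > 100000 nM, and no number (the limit of > 100000 nM in this assay, at which 1 of the 3 values shown sits).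

Compound 4, `ClCc1ccc(Cn2cnc3c(Cl)nc(Cl)nc32)cc1`, has not yet been tested. It differs from compound 1 by chloro in place of hydrogen on an aromatic carbon, the one that sits between two ring nitrogen atoms, meta to a chloro group, meta to a fused ring and para to a fused ring.

The step from compound 1 to compound 4 is expected to raise the number by a 1.9-fold higher number from compound 1 to compound 4 (0.27 log units; within the scatter), because compound 3 gives 79400 nM with two chlorines on its core. Compound 4 is therefore expected to give about 50000 nM, within 15000 nM to 150000 nM.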

Compound 4, concentration lethal to 50% of the cells: 28800 nM
Estimate against measurement, compound 4: 1.7-fold (0.24 log units) above; measured number inside the range.
By their numbers in this assay, from the lowest: compounds 1 and 4 (each within the scatter of the next); then compound 3. At a limit, above all of these: compound 2.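

In this assay, chloro in place of hydrogen on the aromatic carbon between two ring nitrogen atoms gives a 1.1-fold higher number from compound 1 to compound 4 (0.03 log units; within the scatter), so compound 1 and compound 4 cannot be told apart in this test. This is the first reading of a single change among these compounds, as no earlier pair differed in one place. At this position, a second chlorine on the core of compound 1 leaves the lethal concentration within the scatter.

The compounds shown leave open whether an amine, a methoxy group or a longer chain on this same carbon would also stay within the scatter in this assay. Nothing measured here accounts for the result at this position.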